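Naphthalen-2-yl replacing phenyl on the shared core

The source may hold more compounds than are shown below. What is called first, only, known or untested is meant among the compounds shown, and "the series" means these compounds.

Measured compounds and their values:
- compound 1, `O=C1N=C(N2N=C(c3ccccc3)CC2c2ccccc2O)S/C1=C1/C(=O)Nc2ccc(Br)cc21`: 800 nM
- compound 2, `COc1ccc(C2CC(c3ccccc3)=NN2C2=NC(=O)/C(=C3\C(=O)Nc4ccccc43)S2)cc1`: 4580 nM
- compound 3, `COc1ccc(C2CC(c3ccccc3)=NN2C2=NC(=O)/C(=C3\C(=O)Nc4ccc(Br)cc43)S2)cc1`: 480 nM

In a functional assay on cells (Cancer cell lines, Homo sapiens) for cytotoxicity, read by sulforhodamine B assay, with a stated time of 48 h (a lower number here means a stronger inhibitor of growth, a higher number a weaker inhibitor of growth), compound 3 has the lowest number of the three, though its gap to compound 1 is within the scatter, as a 1.7-fold lower number from compound 1 to compound 3 (0.22 log units; within the scatter) shows. Only the gap to compound 2 is beyond the scatter: a 9.5-fold lower number from compound 2 to compound 3 (0.98 log units; beyond the scatter). Among the measured compounds shown here, these are the only two steps measured, and neither touches the group on the carbon with a double bond to nitrogen.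

Compound 4, `COc1ccc(C2CC(c3ccc4ccccc4c3)=NN2C2=NC(=O)/C(=C3\C(=O)Nc4ccc(Br)cc43)S2)cc1`, differs from compound 3 at exactly that site: naphthalen-2-yl in place of phenyl on a carbon with a double bond to nitrogen. For the measured compounds named here, no measured step bears on this change directly. Going by the values given here, the one change at an aryl group, from compound 1 to compound 3, sits on a different ring carbon and stayed within the scatter; the bromo step lies elsewhere again. Among the compounds with values here, without a precedent for the larger aromatic group, the working expectation is no step in this assay beyond the scatter, so compound 4 is expected near compound 3, the estimated step being a 1.1-fold lower number from compound 3 to compound 4 (0.03 log units; within the scatter). Compound 4 is therefore estimated at 450 nM, with a range from 150 nM to 1500 nM.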

Compound 4, concentration for total growth inhibition: 990 nM
The estimate for compound 4 lay 2.2-fold (0.34 log units) below the measured number; the range from low to high includes it.
By their numbers in this assay, from the lowest: compounds 3, 1 and 4 (each within the scatter of the next, the first and the last beyond it); then compound 2.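

In this assay, the group on the carbon with a double bond to nitrogen now has its first measured change: naphthalen-2-yl in place of phenyl gives a 2.1-fold higher number from compound 3 to compound 4 (0.31 log units; beyond the scatter). The step lies beyond the scatter but is modest, and it is smaller than the bromo change, a 9.5-fold lower number from compound 2 to compound 3 (0.98 log units; beyond the scatter), so on this pair the second six-membered aromatic ring brings no lower number, while the value stays of the same order as that of compound 3. No measurement offered here accounts for this step, so the result stands as an observation on a single pair.

As far as these compounds go, what remains open is whether the higher number follows from the added ring at this position or is specific to naphthalen-2-yl, since a single replacement cannot separate the two, and a methyl group, a 4-fluorophenyl group or a morpholine-bearing phenyl group at the same carbon would help to define the trend. Also open, from the compounds shown here alone, is whether the step carries over to the cores with 2-hydroxyphenyl on the saturated ring carbon or with hydrogen in place of bromo.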